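The source may hold more compounds than are shown below. What is called first, only, known or untested is meant among the compounds shown, and "the series" means these compounds.

In a functional assay on Jurkat cells (Homo sapiens) for antiproliferative activity, read by MTT assay and trypan blue exclusion, with a stated time of 72 h; a lower number here means a stronger inhibitor, a higher number a weaker inhibitor:
compound 1 `COC(=O)c1ccc(C2SCC(=O)N2c2ccc(N3CCN(S(=O)(=O)c4ccccc4)CC3)cn2)c(OC)c1` gives 52900 nM
compound 2 `COC(=O)c1ccc(C2SCC(=O)N2c2ccc(N3CCN(S(=O)(=O)c4ccc([N+](=O)[O-])cc4)CC3)cn2)c(OC)c1` gives 54000 nM
compound 3 `COC(=O)c1ccc(C2SCC(=O)N2c2ccc(N3CCN(Cc4cc(OC)c(OC)c(OC)c4)CC3)cn2)c(OC)c1` gives 41000 nM

Compound 1 stands second highest of the three numbers; its nearest neighbour is compound 2 and its furthest is compound 3, and both gaps lie within the scatter. Among the measured compounds shown here, the only measured single-point step, a 1.0-fold higher number from compound 1 to compound 2 (0.01 log units; within the scatter), leaves the ring nitrogen in question untouched. Compound 4 `COC(=O)c1ccc(C2SCC(=O)N2c2ccc(N3CCN(Cc4ccc(Cl)c(Cl)c4)CC3)cn2)c(OC)c1` differs from compound 1 by 3,4-dichlorobenzyl in place of phenylsulfonyl on an amine nitrogen in a ring. For the measured compounds named here, compound 3, where that ring nitrogen likewise carries something other than phenylsulfonyl, shows a number within the scatter of compound 1, but no measured step covers this exact exchange. No step beyond the scatter is therefore expected in this assay. Compound 4 is estimated at 45000 nM, with a range from 20000 nM to 100000 nM. The expected step is a 1.2-fold lower number from compound 1 to compound 4 (0.07 log units; within the scatter).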

Compound 4, half-maximal inhibitory concentration: 61000 nM
Beside the measured number, compound 4's estimate is 1.4-fold (0.13 log units) below it; the range from low to high includes it.
By their numbers in this assay, from the lowest: compounds 3, 1, 2 and 4 (each within the scatter of the next).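

On the amine nitrogen in the ring, 3,4-dichlorobenzyl in place of phenylsulfonyl gives a 1.2-fold higher number from compound 1 to compound 4 (0.06 log units; within the scatter) in this assay and in place of (4-nitrophenyl)sulfonyl gives a 1.1-fold higher number from compound 2 to compound 4 (0.05 log units; within the scatter) in the same read-out. Among the two benzyl-type groups, 3,4-dichlorophenyl in place of 3,4,5-trimethoxyphenyl gives a 1.5-fold higher number from compound 3 to compound 4 (0.17 log units; within the scatter) and so extends the flat picture to a change of the aromatic ring's substituents. No evidence on these results is available.

Open, as far as these compounds go, is whether an aminoalkyl or carboxymethyl group on that ring nitrogen would give a step beyond the scatter. Also open, from the compounds shown here alone, is whether a carboxylic acid in place of the methyl ester would do so.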